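A few compounds are considered here, and "the series" means these few. Any claim that something is new, unique, unknown or untested is made for them only; others in the source may bear on it.

Three measured compounds and one not yet measured share the core shown in compound 1 `Cn1ccc2c(Oc3ccc(NC(=O)c4nn(-c5ccc(Br)cc5)ccc4=O)cc3)ccnc21`. In a functional assay on HepG2 cells (Homo sapiens) for cytotoxicity, read by MTT assay, with a stated time of 72 h (a higher number here means a weaker inhibitor, a lower number a stronger inhibitor), compound 1 gives 39200 nM. Compound 2 `Cn1ccc2c(Oc3ccc(NC(=O)c4nn(-c5ccc(Cl)cc5)ccc4=O)cc3F)ccnc21` carries a chloro group and an added fluoro group; in this assay compound 2 reaches only the limit of > 60000 nM. Compound 3 `COc1ccc(-n2ccc(=O)c(C(=O)Nc3ccc(Oc4ccnc5c4ccn5C)c(F)c3)n2)cc1` has a methoxy in place of the chloro; in this assay compound 3 likewise reaches only the limit of > 60000 nM. The step that the two limits leave unreadable from compound 2 to compound 3 is unreadable because of the limit of > 60000 nM in this assay, at which 2 of the 3 values shown sit. Compound 3 thus stands at the limit, and one of the other two values shown sits there as well, so no number places it against its neighbours.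

Compound 4 `Cn1ccc2c(Oc3ccc(NC(=O)c4nn(-c5ccc(Br)cc5)ccc4=O)cc3F)ccnc21` differs from compound 3 by bromo in place of methoxy on an aromatic carbon. For the measured compounds named here, no measured step reads this exchange directly, and the one step at this place, a step that the two limits leave unreadable from compound 2 to compound 3, cannot be sized. Compound 4 is therefore expected to remain near the limit, with an estimated step of an at least 1.0-fold lower number from compound 3 to compound 4 (0.03 log units; that floor lies within the scatter). The estimate for compound 4 is 55000 nM, within a range from 25000 nM to 130000 nM.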

Compound 4, half-maximal inhibitory concentration: > 60000 nM
Compound 4 was reported as a limit; the forecaster's own chance of this, stated with the estimate: 55%; at least 1.0-fold (0.03 log units) between middle value and limit.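

For the compounds shown here, compound 4 gives the only step here that can be sized, and it concerns the fluoro group rather than the group on the outer phenyl ring: an at least 1.5-fold higher number from compound 1 to compound 4 (0.18 log units; that floor lies within the scatter). Since that floor lies within the scatter, the pair does not establish that fluoro in place of hydrogen changes the reading in this assay. At the aromatic carbon para to a large group, bromo now joins chloro and methoxy at the same limit, so none of the steps among compound 2, compound 3 and compound 4 can be read: the limit of > 60000 nM in this assay, at which 3 of the 4 values shown sit.

Going by these compounds, it remains open whether these three groups differ at all at this place, since the limit hides any gap among them. Also open, on these data alone, is how an amine or a carboxylic acid at this carbon would read in this assay.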